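Lengthening the chain on the ring nitrogen of compound 3

A few compounds are considered here, and "the series" means these few. Any claim that something is new, unique, unknown or untested is made for them only; others in the source may bear on it.

Three compounds of one core have been run in a functional assay on the whole organism with Rattus norvegicus as the target; on this read-out lower numbers stand for an effect already at smaller amounts and higher numbers for an effect only at larger amounts of compound. Compound 1 `Cc1nn(C)c2c1C(c1ccccc1Cl)=NCC(=O)N2` gives 16 mg/kg, compound 2 `CCCn1nc(C)c2c1NC(=O)CN=C2c1ccccc1Cl` gives 63 mg/kg, and compound 3 `Cc1nn(C(C)C)c2c1C(c1ccccc1Cl)=NCC(=O)N2` gives 16 mg/kg. Compound 3 stands level with compound 1, and the two together hold the lowest numbers of the three; the step of a 3.9-fold lower number from compound 2 to compound 3 (0.60 log units; beyond the scatter) shows that compound 2 is the furthest from compound 3.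

Compound 4 `CCCCn1nc(C)c2c1NC(=O)CN=C2c1ccccc1Cl` differs from compound 3 by butyl in place of isopropyl on an aromatic nitrogen. Among the compounds with values here, two measured steps bear on this change. The step of a 3.9-fold lower number from compound 2 to compound 3 (0.60 log units; beyond the scatter) shows that replacing the propyl chain by the branched isopropyl lowers the number; the step of a 3.9-fold higher number from compound 1 to compound 2 (0.60 log units; beyond the scatter) shows that a longer unbranched chain on this nitrogen raises it. Compound 4 carries a chain that is unbranched again and one carbon longer than propyl, so a step in this assay back toward or beyond the number of compound 2 is expected, in the direction of higher values.

For compound 4 the step from compound 3 is estimated as a 3.1-fold higher number from compound 3 to compound 4 (0.49 log units; beyond the scatter), and the value expected in this assay is 50 mg/kg, within the range 16 mg/kg to 125 mg/kg.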

Compound 4, minimum effective dose: 32 mg/kg
Compound 4: the middle estimate sits 1.6-fold (0.19 log units) above what was measured; low and high end bracket the measured number.
By their numbers in this assay, from the lowest: compounds 1, 3, 4 and 2 (each within the scatter of the next, the first and the last beyond it).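

In this assay, butyl in place of isopropyl on the aromatic nitrogen gives a 2.0-fold higher number from compound 3 to compound 4 (0.30 log units; within the scatter), so at this position the unbranched butyl chain cannot be told apart from the branched isopropyl group. Compound 4 is not separated from the other two compounds either: methyl in place of hydrogen on the saturated chain carbon, three bonds along the chain from the aromatic nitrogen, gives a 2.0-fold lower number from compound 2 to compound 4 (0.29 log units; within the scatter), and propyl in place of hydrogen on the chain carbon bound to that nitrogen gives a 2.0-fold higher number from compound 1 to compound 4 (0.30 log units; within the scatter). Compound 4 thus lies within the scatter of both compound 1 and compound 2, although those two stand apart by a 3.9-fold higher number from compound 1 to compound 2 (0.60 log units; beyond the scatter), so the gap seen earlier between the short and the propyl chain does not settle where butyl belongs, and these compounds show no steady trend with chain length.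

Going by these compounds, it remains open whether a longer chain such as hexyl, a branched tert-butyl group or a chain ending in an amine on this nitrogen would move clearly away from compound 1. Nothing at hand accounts for any of these numbers.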